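This account rests on a few compounds, and the source may have more. Where it says the series, first, only, none or still open, it means among the compounds named here.

Notes on the cytotoxicity series. Compound 1 `O=[N+]([O-])c1ccc(-c2nnc(-c3cccnc3)n2Nc2nc3cc(Cl)c(Cl)cc3s2)cc1` gives 68.7 ug/mL in an ADME assay on MT4 cells (Homo sapiens) for cytotoxicity, read by MTT assay, with a stated time of 5 days; on this read-out higher numbers stand for lower toxicity in this test and lower numbers for higher toxicity in this test. Compound 2 `Cc1ccc2nc(Nn3c(-c4ccc(Cl)cc4)nnc3-c3cccnc3)sc2c1` gives 75.5 ug/mL in this assay, and compound 3 `Clc1ccc(-c2nnc(-c3cccnc3)n2Nc2nc3ccc(Cl)cc3s2)cc1` gives 54.3 ug/mL. The three numbers sit within the usual scatter of one another, so compound 3 stands alongside compound 1 and compound 2 rather than apart from them. For the measured compounds named here, the only single-point step measured, a 1.4-fold lower number from compound 2 to compound 3 (0.14 log units; within the scatter), was within the scatter. Compound 4 `Clc1ccc(-c2nnc(-c3cccnc3)n2Nc2nc3cc(Cl)c(Cl)cc3s2)cc1` is the next member; the change is chloro in place of hydrogen on an aromatic carbon. Going by the values given here, no measured step tests a chloro entering at this place, and the one step available was flat, so no movement beyond the scatter is expected: the estimated step of a 1.0-fold higher number from compound 3 to compound 4 (0.01 log units; within the scatter) is small. Compound 4 is expected to give about 55 ug/mL, between 30 ug/mL and 100 ug/mL.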

Compound 4, half-maximal cytotoxic concentration: 52.1 ug/mL
Compound 4: middle estimate off by 1.1-fold (0.02 log units), on the high side, within the range that was stated.
By their numbers in this assay, from the lowest: compounds 4, 3, 1 and 2 (each within the scatter of the next).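

In this assay, for the compounds shown here, the step of a 1.0-fold lower number from compound 3 to compound 4 (0.02 log units; within the scatter) is the first reading at this position, on an aromatic carbon ortho to a chloro group, and it shows a second chloro here leaves the number flat. Chloro in place of nitro, a 1.3-fold lower number from compound 1 to compound 4 (0.12 log units; within the scatter) on the printed values, is likewise within the scatter and adds a second flat exchange to the series. No supporting data bear on these results. As far as these compounds go, whether an amine or a carboxylic acid at this position would give a step beyond the scatter remains open.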